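This account rests on a few compounds, and the source may have more. Where it says the series, first, only, none or still open, it means among the compounds named here.

Compounds measured in an assay on isolated protein for displacement of a labelled ligand from metabotropic glutamate receptor 5 (Homo sapiens), with a stated time of 60 min, tested at 1 uM; a lower number here means less inhibition, a higher number more inhibition at the concentration tested (going by the name of the read-out):

Compound 1, `Cc1ccc(S(=O)(=O)c2cnc3ccc(Cl)cc3c2N2CCC(C)CC2)cc1`: 95%
Compound 2, `Cc1ccc(S(=O)(=O)c2cnc3c(F)cccc3c2N2CCC(C)CC2)cc1`: 93%
Compound 3, `CC1CCN(c2c(S(=O)(=O)c3ccc(F)c(F)c3)cnc3ccc(Cl)cc23)CC1`: 72%

Compound 4, `CC1CCN(c2c(S(=O)(=O)c3ccccc3)cnc3c(F)cccc23)CC1`, has not yet been tested in this assay.

Compound 2 stands second of the three numbers. Compound 1 lies close to it, and the two values fall within the usual scatter, so no order between them can be read. Compound 3 lies beyond the scatter below compound 2.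

Compound 4 differs from compound 2 in one place: hydrogen in place of methyl on an aromatic carbon. The core of compound 2 and the rest of the molecule are kept.

Among the measured compounds shown here, only one measured step touches the aryl group on the sulfonyl sulfur: a number 23 percentage points lower from compound 1 to compound 3 (beyond the scatter). That step exchanges the whole 4-methylphenyl for 3,4-difluorophenyl and is larger than the change to compound 4, which only removes the methyl to leave phenyl. For the measured compounds named here, no measured pair shows the methyl alone being taken away. On this basis the step to compound 4 is expected to be small and, if anything, downward, most likely within the scatter, so that the estimated step is a number 7 percentage points lower from compound 2 to compound 4 (within the scatter).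

Compound 4 is therefore expected to give about 86% in this assay, estimated between 72% and 96%.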

Compound 4, a percentage reported as inhibition, at one concentration (the size of the read-out at that concentration, not a potency): 13%
The estimate for compound 4 lay 73 percentage points above the measured number; the measured number lies below the stated range.
By their numbers in this assay, from the lowest: compound 4; then compound 3; then compounds 2 and 1 (each within the scatter of the next).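

In this assay the change from 4-methylphenyl to phenyl, with the rest of the molecule kept, gives a number 80 percentage points lower from compound 2 to compound 4 (beyond the scatter) and so forms the only step shown that takes away this methyl alone. The earlier step on the sulfonyl sulfur, a number 23 percentage points lower from compound 1 to compound 3 (beyond the scatter), exchanged the whole aryl group and could not show what a single carbon at this place contributes; here the loss of one heavy atom, with no hydrogen-bond donor or acceptor and no net charge leaving, separates a high number from a low one. No measurement at hand bears on why so small a change has so large a result.

The compounds shown leave open whether the same change on the core of compound 1, which carries the chlorine, would give a step of similar size. They also leave open how far the number depends on methyl itself at this place, on an aromatic carbon para to a large group: ethyl, methoxy, chlorine or an amine there could each be set against compound 2.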